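The source may report more compounds than this note shows. Statements on the series, on what has been measured and on what is new or still open speak of the compounds shown alone.

Compound 1 `CC(=O)c1ccc(NC(=O)Cn2nc(-c3ccc(Cl)cc3)nc2N)cc1`: 10.4%
Compound 2 `C/C(=N/O)c1ccc(NC(=O)Cn2nc(C(F)(F)F)nc2N)cc1`: 11.9%
Compound 3 `C/C(=N/O)c1ccc(NC(=O)Cn2nc(-c3ccccc3)nc2N)cc1`: 13.9%

In a functional assay on HT-29 cells (Homo sapiens) for inhibition, read by sulforhodamine B assay, with a stated time of 48 h, tested at 10 uM (on this read-out lower numbers stand for less inhibition of growth and higher numbers for more inhibition of growth at the one concentration tested), compound 2 gives 11.9%, within the scatter of both compound 1 and compound 3. Compound 4 `CC(=O)c1ccc(NC(=O)Cn2nc(C(F)(F)F)nc2N)cc1` departs from compound 2 by a group of 3 heavy atoms (2 carbon, 1 oxygen; no ring) in place of a group of 4 heavy atoms (2 carbon, 1 nitrogen, 1 oxygen; no ring), on an aromatic carbon, on an aromatic carbon, para to a large group. For the measured compounds named here, no measured step tests this change directly. Going by the values given here, the one measured step, a number 2 percentage points higher from compound 2 to compound 3 (within the scatter), lies elsewhere in the molecule and is small. Compound 1 already carries acetyl and gives 10.4%. On these grounds the expected change is none beyond the scatter, an expected a number 0.9 percentage points lower from compound 2 to compound 4 (within the scatter). Compound 4 is estimated at 11%, with an expected range of 2% to 22%.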

Compound 4, percent growth inhibition at one concentration: 16%
Compound 4: middle estimate off by 5 percentage points, on the low side; the measured number falls inside the stated range.
By their numbers in this assay, from the lowest: compounds 1, 2, 3 and 4 (each within the scatter of the next).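

In this assay, acetyl in place of the group of 4 heavy atoms, on the aromatic carbon para to a large group, gives a number 4.1 percentage points higher from compound 2 to compound 4 (within the scatter), so this exchange does not separate from the scatter. With acetyl held in place, trifluoromethyl in place of 4-chlorophenyl gives a number 5.6 percentage points higher from compound 1 to compound 4 (within the scatter), and that exchange also stays inside the scatter. No measurement at hand bears on the origin of either step.

Open, from the compounds shown here alone, is whether an amine or a carboxylic acid at this position would give a step beyond the scatter.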